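Nitro for Methyl on the Sulfonyl Aryl Ring

The compounds below may be only part of what the source reports. "The series", "measured", "known", "first", "only" and "open" are said of these compounds alone.

Compound 1 `CC(=O)c1ccc(NC(=O)C(CC(C)C)N(C(=O)c2ccccc2)S(=O)(=O)c2ccc(C)cc2)cc1` stands second highest of the three numbers in a functional assay, read by spectrophotometry, with a stated time of 20 min (a higher number here means a weaker inhibitor, a lower number a stronger inhibitor), where compound 1 gives 11000000 nM. Compound 2 `CCC(C)C(C(=O)Nc1ccc(C(C)=O)cc1)N(C(=O)c1ccccc1)S(=O)(=O)c1ccc(C)cc1` gives 10000000 nM, and compound 3 `CC(=O)c1ccc(NC(=O)C(C(C)C)N(C(=O)c2ccccc2)S(=O)(=O)c2ccc(C)cc2)cc1` gives 12000000 nM. The steps of a 1.1-fold lower number from compound 1 to compound 2 (0.04 log units; within the scatter) and a 1.1-fold higher number from compound 1 to compound 3 (0.04 log units; within the scatter) lie within the scatter, as does a 1.2-fold higher number from compound 2 to compound 3 (0.08 log units; within the scatter). Compound 4 `CC(=O)c1ccc(NC(=O)C(CC(C)C)N(C(=O)c2ccccc2)S(=O)(=O)c2ccc([N+](=O)[O-])cc2)cc1` differs from compound 1 by nitro in place of methyl on an aromatic carbon. Within the data shown here, none of the measured steps touches this part of the molecule; all three alter the saturated chain carbon bound to the amide-type nitrogen and the carbonyl carbon, and none moved the number beyond the scatter. Among the measured compounds shown here, no measured step bears on the sulfonyl aryl change, so compound 4 is expected to show a step of no change at the digits printed from compound 1 to compound 4 (within the scatter). The estimate for compound 4 is 11000000 nM, with a range from 4000000 nM to 30000000 nM.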

Compound 4, half-maximal inhibitory concentration: 8400000 nM
For compound 4 the middle estimate is 1.3-fold (0.12 log units) above the measured one; the range from low to high includes it.
By their numbers in this assay, from the lowest: compounds 4, 2, 1 and 3 (each within the scatter of the next).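

Among these compounds, the sulfonyl aryl ring, untouched in the earlier compounds, now shows its first step: in this assay, nitro in place of methyl on the aromatic carbon para to a large group gives a 1.3-fold lower number from compound 1 to compound 4 (0.12 log units; within the scatter). Like the changes on the saturated chain carbon, this exchange of one heavy atom for three stays within the scatter. No evidence on hand bears on this result. The compounds shown hold only methyl and nitro at this carbon, so how an amine or a carboxylic acid there would read remains open.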